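A fluoro to chloro exchange on compound 1

The source may hold more compounds than are shown below. What is called first, only, known or untested is meant among the compounds shown, and "the series" means these compounds.

Compound 1 `COc1cc(-c2nc(-c3ccccc3)[nH]c2-c2ccnc(NCCCNS(=O)(=O)c3ccccc3)n2)ccc1F`: 4520 nM
Compound 2 `COc1cc(-c2nc(-c3ccccc3)[nH]c2-c2ccnc(NCCCNS(=O)(=O)c3ccc(Cl)cc3)n2)ccc1F`: 83100 nM

Both compounds were tested in a functional assay on LOX IMVI cells (Homo sapiens) for cytotoxicity, read by MTT assay, with a stated time of 24 h (on this read-out higher numbers stand for weaker inhibition and lower numbers for stronger inhibition), and compound 1 holds the lower of the two numbers at 4520 nM. Compound 3 `COc1cc(-c2nc(-c3ccccc3)[nH]c2-c2ccnc(NCCCNS(=O)(=O)c3ccccc3)n2)ccc1Cl` has not yet been measured. It replaces the 4-fluoro-3-methoxyphenyl of compound 1 with 4-chloro-3-methoxyphenyl: chloro in place of fluoro on an aromatic carbon.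

Among the compounds with values here, only one measured step bears on this change, and only loosely. The large step of an 18-fold higher number from compound 1 to compound 2 (1.26 log units; beyond the scatter) came from chloro in place of hydrogen on an aromatic carbon, at another place in the molecule. It suggests that adding chloro need not be tolerated, but it is a single case of a different exchange. In this assay, a much smaller move towards a higher number is therefore expected. The estimated step is a 1.5-fold higher number from compound 1 to compound 3 (0.19 log units; within the scatter). The expected value for compound 3 is 7000 nM, within an estimated range of 1800 nM to 30000 nM.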

Compound 3, half-maximal inhibitory concentration: 7470 nM
Beside the measured number, compound 3's estimate is 1.1-fold (0.03 log units) below it; the range from low to high includes it.
By their numbers in this assay, from the lowest: compounds 1 and 3 (each within the scatter of the next); then compound 2.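

In this assay the exchange of 4-fluoro-3-methoxyphenyl for 4-chloro-3-methoxyphenyl gives a 1.7-fold higher number from compound 1 to compound 3 (0.22 log units; within the scatter) and so separates chloro from fluoro at this position by no more than repeated measurements would. The earlier step, an 18-fold higher number from compound 1 to compound 2 (1.26 log units; beyond the scatter) as chloro replaced hydrogen elsewhere in the molecule, therefore does not carry over to this aromatic carbon, ortho to a methoxy group. Nothing measured here explains why the two places differ.

Going by these compounds, it remains open whether a group other than a halogen, such as an amine or a hydroxyl, would stay as close to compound 1 at this position. Also open, on these data alone, is whether the chloro of compound 2 would have the same large effect in a molecule that also carries chloro at this position.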